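Phenol in Place of Acetamide on the Biaryl of Compound 3

This account rests on a few compounds, and the source may have more. Where it says the series, first, only, none or still open, it means among the compounds named here.

Measured compounds in a functional assay for antagonist activity at thromboxane A2 receptor (Rattus norvegicus); a higher number here means weaker binding, a lower number tighter binding:
- compound 1, `CS(=O)(=O)Nc1cccc(-c2ccc(COC3CC[C@H](N4CCCCCC4)[C@H]3OC/C=C\CCC(=O)O)cc2)c1`, gives 50.1 nM
- compound 2, `O=C(O)CC/C=C\CO[C@H]1C(OCc2ccc(-c3ccccc3CO)cc2)CC[C@@H]1N1CCCCCC1`, gives 6.31 nM
- compound 3, `NC(=O)Cc1ccccc1-c1ccc(COC2CC[C@H](N3CCCCCC3)[C@H]2OC/C=C\CCC(=O)O)cc1`, gives 158 nM

Compound 3 stands highest of the three numbers in this assay. Compound 1 is its nearest neighbour, the two being separated by the step of a 3.2-fold higher number from compound 1 to compound 3 (0.50 log units; beyond the scatter), and compound 2 is the furthest, separated by the large step of a 25-fold higher number from compound 2 to compound 3 (1.40 log units; beyond the scatter).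

Compound 4 is `O=C(O)CC/C=C\CO[C@H]1C(OCc2ccc(-c3ccccc3O)cc2)CC[C@@H]1N1CCCCCC1`. It differs from compound 3 in one place: hydroxy in place of carbamoylmethyl on an aromatic carbon. The step that bears most on this change is a 25-fold higher number from compound 2 to compound 3 (1.40 log units; beyond the scatter), where carbamoyl in place of hydroxy on a saturated chain carbon bound to an aromatic carbon gave a much higher number. Compound 4 partly reverses that change, but its hydroxy sits directly on the aromatic carbon rather than on the saturated chain carbon, so the reversal is not exact. The step of a 7.9-fold lower number from compound 1 to compound 2 (0.90 log units; beyond the scatter) also shows that a hydroxy-bearing group in this position goes with a low number. The writer therefore expects a clear fall for compound 4, a 13-fold lower number from compound 3 to compound 4 (1.12 log units; beyond the scatter), probably stopping short of compound 2. The estimate for compound 4 in this assay is 12 nM, in the range 3 nM to 45 nM.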

Compound 4, dissociation constant: 20 nM
Beside the measured number, compound 4's estimate is 1.7-fold (0.22 log units) below it, and the stated range covers the measured number.
By their numbers in this assay, from the lowest: compound 2; then compound 4; then compound 1; then compound 3.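

In this assay, for the compounds shown here, the step of a 7.9-fold lower number from compound 3 to compound 4 (0.90 log units; beyond the scatter) shows that a hydroxy set directly on the aromatic carbon, ortho to a large group, goes with a much lower number than carbamoylmethyl, whereas the earlier compounds showed a hydroxy only on a saturated chain carbon. The hydroxy group's exact placement also matters, since replacing hydroxymethyl with hydroxy gives a 3.2-fold higher number from compound 2 to compound 4 (0.50 log units; beyond the scatter), leaving compound 2 lowest of the four, while 2-hydroxyphenyl in place of 3-(methanesulfonamido)phenyl still gives a 2.5-fold lower number from compound 1 to compound 4 (0.40 log units; beyond the scatter). No measurement is available here that would account for the size of any of these steps.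

The compounds shown leave open how a longer chain ending in hydroxy, such as 2-hydroxyethyl, would compare with hydroxymethyl on the same aromatic carbon. They also leave open whether a methoxy group, an amine or a carbamoyl group attached directly to that carbon would track the hydroxy of compound 4 or the carbamoylmethyl of compound 3.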